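Methylating the Indole Nitrogen of Compound 1

The compounds below may be only part of what the source reports. "The series", "measured", "known", "first", "only" and "open" are said of these compounds alone.

The measured compounds and their values in an assay on a protein complex for inhibition of CDK8/Cyclin C (Homo sapiens), with a stated time of 1 h (a lower number here means a stronger inhibitor, a higher number a weaker inhibitor), are:
compound 1, `CCOC(=O)/C=C/c1ccncc1-c1ccc2[nH]ccc2c1`, 107 nM
compound 2, `O=C(O)/C=C/c1ccncc1-c1ccc2cc[nH]c2c1`, 2.4 nM
compound 3, `NC(=O)/C=C/c1ccncc1-c1ccc2ccccc2c1`, 10.5 nM

Among these three, compound 1 gives the highest number in this assay. Its nearest neighbour is compound 3 with 10.5 nM, a gap that lies beyond the usual scatter, and compound 2 with 2.4 nM lies furthest from it, also beyond the scatter. The three differ from one another in more than one place. No single change is shown for any of these gaps.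

Compound 4, `CCOC(=O)/C=C/c1ccncc1-c1ccc2c(ccn2C)c1`, differs from compound 1 in one place only: methyl in place of hydrogen on an aromatic nitrogen. For the measured compounds named here, no measured pair in this set shows what such a change does, so the expectation rests on compound 1 alone. Compound 4 is expected to stay close to compound 1, with the step of a 1.4-fold higher number from compound 1 to compound 4 (0.15 log units; within the scatter) small and not clearly beyond the scatter. The estimate for compound 4 in this assay is 150 nM, within a range from 40 nM to 600 nM.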

Compound 4, half-maximal inhibitory concentration: 144 nM
Beside the measured number, compound 4's estimate is 1.0-fold (0.02 log units) above it, within the range that was stated.
By their numbers in this assay, from the lowest: compound 2; then compound 3; then compounds 1 and 4 (each within the scatter of the next).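

Measured in this assay the change gives a 1.3-fold higher number from compound 1 to compound 4 (0.13 log units; within the scatter) and this lies within the scatter, so methyl in place of hydrogen on the aromatic nitrogen of the five-membered aromatic ring leaves no readable change in the number. The earlier compounds shown here differ from one another in more than one place and could not isolate any single position, whereas this pair shows that, with the ethyl ester in place, the hydrogen on this nitrogen can be replaced by methyl without a shift beyond the scatter. Nothing at hand explains why this change leaves the number where it is.

Going by these compounds, the result covers only methyl, so what an ethyl group, a longer chain or an acetyl group on this nitrogen would do remains open. It also rests on the ethyl ester alone, and whether methyl on this nitrogen has an equally small effect when a carboxylic acid or a primary amide stands in place of that ester cannot be told from these compounds.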